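The source may hold more compounds than are shown below. What is called first, only, known or untested is meant among the compounds shown, and "the series" means these compounds.

In a functional assay on A549 cells (Homo sapiens) for inhibition, read by sulforhodamine B assay, with a stated time of 48 h (on this read-out lower numbers stand for stronger inhibition and higher numbers for weaker inhibition), three related compounds have been measured. Compound 1 (`COc1cc2c(cc1CC1OC1(C)C)C(=O)C[C@@H](c1ccc(O)cc1)O2`) gives 29800 nM, compound 2 (`COc1cc2c(cc1CC=C(C)C)/C(=N/NC(N)=O)C[C@@H](c1ccc(O)cc1)O2`) gives 25300 nM and compound 3 (`COc1ccc([C@@H]2C/C(=N/OCc3cn(-c4ccccc4CO)nn3)c3cc(CC=C(C)C)c(OC)cc3O2)cc1`) gives 30700 nM. Compound 2 therefore sits within the usual scatter of both other compounds, and the three numbers cannot be ranked.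

Compound 4 (`COc1cc2c(cc1CC=C(C)C)/C(=N/O)C[C@@H](c1ccc(O)cc1)O2`) departs from compound 2 in one place: hydroxy in place of ureido on a double-bonded nitrogen. This puts hydroxy in place of ureido on a double-bonded nitrogen. Among the compounds with values here, no measured pair isolates this change, so the data give no direct step to draw on. Within the data shown here, the only indirect guide is that the measured compounds differ from one another in several places, yet their values remain within the scatter. Compound 3, for example, gives 30700 nM in this assay.

On that basis, no change beyond the scatter is expected in this assay. The estimated step, a 1.2-fold lower number from compound 2 to compound 4 (0.06 log units; within the scatter), is expected to be small. The value expected for compound 4 is 22000 nM, with an estimated range of 9000 nM to 50000 nM.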

Compound 4, half-maximal inhibitory concentration: 11400 nM
Compound 4: the middle estimate sits 1.9-fold (0.29 log units) above what was measured; low and high end bracket the measured number.
By their numbers in this assay, from the lowest: compound 4; then compounds 2, 1 and 3 (each within the scatter of the next).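

Within the data shown here, replacing ureido with hydroxy on a double-bonded nitrogen gives the first step in this assay that lies beyond the scatter, a 2.2-fold lower number from compound 2 to compound 4 (0.35 log units; beyond the scatter), although the step is modest. The earlier compounds shown here differ from one another in several places and could not be ranked, so they did not show that the group on this nitrogen can shift the number on its own. No measurement among the compounds shown accounts for this step.

On these data alone, with only ureido and hydroxy compared at this place, it remains open whether the lower number depends on the presence of hydroxy or simply on the absence of ureido. A methoxy group or an amine on the same double-bonded nitrogen would help separate these two readings, as would a longer chain ending in a carboxylic acid.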